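Compound 3 and the cytotoxicity of two esters

This account rests on a few compounds, and the source may have more. Where it says the series, first, only, none or still open, it means among the compounds named here.

Compound 1 `CC(C)C(=O)Oc1c(C(C)C)cc2c3c1OC(=O)[C@@]31CCCC(C)(C)[C@@H]1CC2`: 105000 nM
Compound 2 `CCCCCCCC/C=C/CCCCCCCC(=O)Oc1c(C(C)C)cc2c3c1OC(=O)[C@@]31CCCC(C)(C)[C@@H]1CC2`: 822000 nM

In an ADME assay on AGS cells (Homo sapiens) for cytotoxicity, read by neutral red uptake, with a stated time of 24 h (a lower number here means a stronger inhibitor, a higher number a weaker inhibitor), compound 1 stands lowest of the two measured compounds at 105000 nM, while compound 2 reads 822000 nM, a gap beyond the usual scatter. Compound 3 `CC(C)c1cc2c3c(c1OC(=O)Cc1c[nH]c4ccccc14)OC(=O)[C@@]31CCCC(C)(C)[C@@H]1CC2` has not yet been measured. It keeps the core of compound 1 and carries (1H-indol-3-yl)methyl in place of isopropyl on a carbonyl carbon. Among the compounds with values here, no measured pair differs in one place only, so the data offer no direct guide to this change. A small move towards a higher number, within or near the scatter, is expected, an estimated 1.5-fold higher number from compound 1 to compound 3 (0.18 log units; within the scatter). That direction rests only on compound 2, which reads 822000 nM. For compound 3 the estimated value is 160000 nM, with an expected range of 50000 nM to 500000 nM.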

Compound 3, half-maximal inhibitory concentration: 85600 nM
For compound 3 the middle estimate is 1.9-fold (0.27 log units) above the measured one; low and high end bracket the measured number.
By their numbers in this assay, from the lowest: compounds 3 and 1 (each within the scatter of the next); then compound 2.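

In this assay, within the data shown here, (1H-indol-3-yl)methyl in place of isopropyl on a carbonyl carbon gives a 1.2-fold lower number from compound 1 to compound 3 (0.09 log units; within the scatter), the only step here that differs in one place. It shows that this position can carry the larger group, with its two aromatic rings and its hydrogen-bond donor, without the reading moving beyond the scatter. Nothing measured here gives a reason for this result.

The compounds shown leave open how an amine or a carboxylic acid carried on this carbonyl carbon would read in this assay. They also leave open whether a benzyl group, with a single six-membered aromatic ring of carbon only, would read like (1H-indol-3-yl)methyl in this assay.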